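The source may hold more compounds than are shown below. What is called first, only, known or untested is meant among the compounds shown, and "the series" means these compounds.

Three compounds built on one shared core were compared in a functional assay on SF-268 cells (Homo sapiens) for cytotoxicity, read by sulforhodamine B assay, with a stated time of 48 h, tested at 10 uM; a higher number here means a weaker effect of the compound at the concentration tested, a lower number a stronger effect. Compound 1 `COc1ccc(-c2cc(/C=C/C(=O)c3ccc(N)cc3)[nH]n2)cc1` gives -29% in this assay. Compound 2 `COc1cc(-c2cc(/C=C/C(=O)c3ccc(N)cc3)[nH]n2)cc(OC)c1OC` gives -55%. Compound 3 `COc1cc(-c2cc(/C=C/C(=O)c3ccc(Cl)c(Cl)c3)[nH]n2)cc(OC)c1OC` gives 60%, the highest of the three numbers, and its gaps to both other compounds lie beyond the scatter: the smaller gap is to compound 1 and the larger to compound 2. Within the data shown here, the single measured step, a number 115 percentage points higher from compound 2 to compound 3 (beyond the scatter), put 3,4-dichlorophenyl in place of 4-aminophenyl on the carbonyl carbon, and it was a large move toward a weaker effect at the tested concentration.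

Compound 4 `COc1cc(-c2cc(/C=C/C(=O)c3ccc(F)c(F)c3)[nH]n2)cc(OC)c1OC` has not yet been measured in this assay. It differs from compound 3 in one place: 3,4-difluorophenyl in place of 3,4-dichlorophenyl on a carbonyl carbon. Among the measured compounds shown here, the one measured step touches the same place on the molecule, but no measured pair exchanges one halogen for another, so the size of this particular change cannot be read directly from the data. A modest move back toward the numbers of compound 1 and compound 2 is expected, smaller than the step seen in a number 115 percentage points higher from compound 2 to compound 3 (beyond the scatter). Compound 4 is therefore estimated to give 30%, within -20% to 70%, which means an expected step of a number 30 percentage points lower from compound 3 to compound 4 (beyond the scatter).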

Compound 4, a percentage reported as activity, at one concentration (the size of the read-out at that concentration, not a potency): 17%
Compound 4: middle estimate off by 13 percentage points, on the high side; the range from low to high includes it.
By their numbers in this assay, from the lowest: compound 2; then compound 1; then compound 4; then compound 3.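

In this assay, the step from 3,4-dichlorophenyl to 3,4-difluorophenyl on the carbonyl carbon is a number 43 percentage points lower from compound 3 to compound 4 (beyond the scatter), so this position responds to which halogen is present and not only to whether the group is a halogen-bearing ring or 4-aminophenyl. The other new step, a number 72 percentage points higher from compound 2 to compound 4 (beyond the scatter), shows that the difluoro group also leaves the number well above that of the 4-aminophenyl group on the same core, and that the earlier large jump was not unique to the dichloro group. Nothing available explains why the two halogen-bearing rings differ at this position.

The compounds shown leave open how the number behaves with an unsubstituted phenyl ring at this place, or with a phenyl ring carrying a dimethylamino group or a carboxylic acid, which would help show whether the amine of 4-aminophenyl matters in itself. They also leave open whether the 3,4-difluorophenyl and 3,4-dichlorophenyl groups would stand in the same order on the core of compound 1.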